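The compounds below may be only part of what the source reports. "The series", "measured", "known", "first", "only" and "open" are said of these compounds alone.

Measured so far:
compound 1 `CC(C)(C)c1ccc(C(=O)N2CCC3(CC2)C(=O)N(CC(=O)N2CCN(S(C)(=O)=O)CC2)CN3c2ccccc2)cc1` gives 19000 nM
compound 2 `O=C(CN1CN(c2ccccc2)C2(CCN(C(=O)c3ccc(C4CCCCC4)cc3)CC2)C1=O)N1CCCCC1` gives 1100 nM
compound 3 `CC(C)(C)OC(=O)NCNC(=O)CN1CN(c2ccccc2)C2(CCN(C(=O)c3ccc(C4CCCCC4)cc3)CC2)C1=O` gives 1700 nM

All three numbers come from an assay on HEK293 cells for displacement of a labelled ligand from NPC1-like intracellular cholesterol transporter 1 (Homo sapiens); a higher number here means a weaker inhibitor, a lower number a stronger inhibitor. Among them compound 1 stands at the highest number, which makes it the weakest inhibitor of the three: its nearest neighbour is compound 3, and its value sits above that of compound 3 and further still above that of compound 2, both gaps lying beyond the usual scatter of the measurement.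

Compound 4 `CC(C)(C)c1ccc(C(=O)N2CCC3(CC2)C(=O)N(CC(=O)NCCCCCNS(C)(=O)=O)CN3c2ccccc2)cc1` has not yet been measured. It differs from compound 1 in a single place: (5-(methanesulfonamido)pentyl)amino in place of 4-(methylsulfonyl)piperazin-1-yl on a carbonyl carbon. Among the measured compounds shown here, only one measured step bears on a change of this sort. From compound 2 to compound 3 a ring amine on a carbonyl carbon was exchanged for an open-chain amine bearing a carbamate: a 1.5-fold higher number from compound 2 to compound 3 (0.19 log units; within the scatter). That step stayed within the scatter, so opening the ring on the amide side gave no clear shift there. Because a 1.5-fold higher number from compound 2 to compound 3 (0.19 log units; within the scatter) was so small, no shift beyond the scatter is expected in this assay either, a 1.3-fold lower number from compound 1 to compound 4 (0.10 log units; within the scatter). Compound 4 is therefore estimated to give 15000 nM, with a range from 5000 nM to 45000 nM.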

Compound 4, half-maximal inhibitory concentration: 5500 nM
Compound 4: middle estimate off by 2.7-fold (0.44 log units), on the high side; low and high end bracket the measured number.
By their numbers in this assay, from the lowest: compounds 2 and 3 (each within the scatter of the next); then compound 4; then compound 1.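

In this assay, replacing the 4-(methylsulfonyl)piperazin-1-yl ring on this carbonyl carbon with the open (5-(methanesulfonamido)pentyl)amino chain gives a 3.5-fold lower number from compound 1 to compound 4 (0.54 log units; beyond the scatter) and so yields a modest but real gain, whereas the earlier ring-to-chain exchange, a 1.5-fold higher number from compound 2 to compound 3 (0.19 log units; within the scatter), produced no clear shift. This position therefore accepts a flexible chain without loss of inhibition, and at least in this pair the open form is the stronger inhibitor, so a ring is not required here. The change swaps a group with 0 hydrogen-bond donors for one with 2 hydrogen-bond donors while removing the ring, and nothing available separates these two differences or explains the lower number.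

The compounds shown leave open how the result depends on the chain itself, for instance whether a butyl or hexyl linker would match the pentyl one. They also leave open whether the methanesulfonamide end is needed at all, or whether a chain ending in a free amine or a carboxylic acid would serve as well.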